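The compounds below may be only part of what the source reports. "The series", "measured", "known", "first", "only" and "open" are said of these compounds alone.

Measured so far:
- compound 1, `CC(Oc1ccccc1-c1ccccc1O)C1=NCCN1`, 1620 nM
- compound 2, `CC(Nc1ccccc1-c1ccccc1)C1=NCCN1`, 708 nM
- compound 3, `CC(Sc1ccccc1-c1ccccc1)C1=NCCN1`, 708 nM

All three share the same core and were tested in an assay on CHO cells for displacement of a labelled ligand from Alpha-2C adrenergic receptor (Homo sapiens); on this read-out lower numbers stand for stronger inhibition and higher numbers for weaker inhibition. Compound 1 shows the highest number of the three. Its nearest neighbours in value are compound 2 and compound 3, which sit at the same number, and each of them lies beyond the scatter away from compound 1, so compound 1 is the weakest binder of this small set.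

Compound 4, `Cc1cccc(-c2ccccc2OC(C)C2=NCCN2)c1`, has not been measured. It differs from compound 1 in one place: 3-methylphenyl in place of 2-hydroxyphenyl on an aromatic carbon. Compound 4 therefore keeps the same core as compound 1, and only the aryl group attached to it is exchanged.

For the measured compounds named here, no measured pair shows this exact exchange, so the expectation rests on the spread of the three numbers alone. The expected step from compound 1 to compound 4 in this assay is a 2.7-fold lower number from compound 1 to compound 4 (0.43 log units; beyond the scatter), a modest move toward a lower number, beyond the scatter but not far. For compound 4 the estimated value in this assay is 600 nM, with a likely range from 150 nM to 2400 nM.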

Compound 4, inhibition constant: 245 nM
For compound 4 the middle estimate is 2.4-fold (0.39 log units) above the measured one, and the stated range covers the measured number.
By their numbers in this assay, from the lowest: compound 4; then compounds 2 and 3 (each within the scatter of the next); then compound 1.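

In this assay the aryl group on this aromatic carbon carries real weight: 3-methylphenyl in place of 2-hydroxyphenyl gives a 6.6-fold lower number from compound 1 to compound 4 (0.82 log units; beyond the scatter) and this step lies beyond the scatter. Both groups count 7 heavy atoms and one six-membered aromatic ring of carbon only, yet the entering group has 0 hydrogen-bond donors and 0 hydrogen-bond acceptors, so the ring at this place needs neither to reach a lower number. The exchange removes the hydroxyl and adds the methyl in a single step, and nothing available explains the fall or divides it between those two parts.

The compounds shown leave open what each part contributes alone, which an unsubstituted phenyl ring at this place would help to separate, and whether moving the methyl elsewhere on the ring changes the number. Also open, on these data alone, is how this assay would respond to other groups on this ring, such as a methoxy group, a chlorine atom, an amine, a carboxylic acid or a longer chain in place of the methyl.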